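Phenoxy for trifluoromethyl on the aniline arm of compound 3

This account rests on a few compounds, and the source may have more. Where it says the series, first, only, none or still open, it means among the compounds named here.

Measured so far in a functional assay on U-87MG ATCC cells for antiproliferative activity against U-87 MG (Homo sapiens), read by spectrophotometry, with a stated time of 2 days; a higher number here means a weaker inhibitor of growth, a lower number a stronger inhibitor of growth:
compound 1 `COc1ccc(Nc2ncc(C(F)(F)F)c(N3Cc4cccc(N(C)S(C)(=O)=O)c4C3)n2)cc1C(F)(F)F` gives 29400 nM.
compound 2 `CN(c1cccc2c1CN(c1nc(Nc3ccc(Cl)c(C(F)(F)F)c3)ncc1C(F)(F)F)C2)S(C)(=O)=O` gives > 30000 nM, which is a limit of the assay.
compound 3 `CN(c1cccc2c1CN(c1nc(Nc3cccc(C(F)(F)F)c3)ncc1C(F)(F)F)C2)S(C)(=O)=O` gives > 30000 nM, which is a limit of the assay.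

Compound 3 therefore stands at the edge of what this assay reports, and the limit of > 30000 nM in this assay, at which 2 of the 3 values shown sit, shows that compound 2 shares that position. Only compound 1 has a numerical value, and even that sits at the weak end. The step of an at least 1.0-fold higher number from compound 1 to compound 3 (0.00 log units; that floor lies within the scatter) is at its floor, and a step that the two limits leave unreadable from compound 2 to compound 3 cannot be read at all, so nothing separates the three within the scatter.

Compound 4 `CN(c1cccc2c1CN(c1nc(Nc3cccc(Oc4ccccc4)c3)ncc1C(F)(F)F)C2)S(C)(=O)=O` is compound 3 with the change (phenoxy in place of trifluoromethyl on an aromatic carbon). All measured steps vary the other substituent on that ring, so none bears on this position directly; the series offers only the observation that every variant so far is at or near the limit. On that basis compound 4 is expected to stay in the same weak region, with an estimate of 30000 nM, ranging from 8000 nM to 100000 nM in this assay. The expected step of a number no higher from compound 3 to compound 4 (the limit leaves the size open) is thus one that the scatter and the limit would not let stand out.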

Compound 4, concentration for 50% growth inhibition: 19500 nM
Compound 4: the middle estimate sits 1.5-fold (0.19 log units) above what was measured; the measured number falls inside the stated range.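

In this assay compound 3 gives > 30000 nM, which is a limit of the assay and not a number. With phenoxy on this aromatic carbon, compound 4 gives a readable value of 19500 nM, so this position accepts a group with more heavy atoms and an added aromatic ring, and the change reads as an at least 1.5-fold lower number from compound 3 to compound 4 (0.18 log units; that floor lies within the scatter). The true size of this step stays unknown because one end of it is a limit, so this floor alone does not set compound 4 apart from compound 3: the limit of > 30000 nM in this assay, at which 2 of the 4 values shown sit.

The series as shown does not separate the contribution of the phenoxy oxygen from that of its aromatic ring, as a single replacement changes both at once. On these data alone, whether an amine, a carboxylic acid or a longer chain such as benzyloxy on the same aromatic carbon would give a step beyond the scatter remains open, as does whether any group here would bring the series out of the weak end of this assay's range.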